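Tert-butyl for cyclohexyl on the aromatic ring of compound 1

The source may hold more compounds than are shown below. What is called first, only, known or untested is meant among the compounds shown, and "the series" means these compounds.

Compound 1 `CCOC(=O)C1CCN(C(=O)CN2CN(c3ccccc3)C3(CCN(C(=O)c4ccc(C5CCCCC5)cc4)CC3)C2=O)CC1` gives 900 nM in an assay on HEK293 cells for displacement of a labelled ligand from NPC1-like intracellular cholesterol transporter 1 (Homo sapiens); a lower number here means a stronger inhibitor, a higher number a weaker inhibitor. Among the three measured compounds it holds the second highest number; compound 2 `O=C(CN1CN(c2ccccc2)C2(CCN(C(=O)c3ccc(C4CCCCC4)cc3)CC2)C1=O)N1CCC(CO)CC1` gives 1100 nM and compound 3 `CC1(C)CC(OC(=O)CN2CN(c3ccccc3)C3(CCN(C(=O)c4ccc(C5CCCCC5)cc4)CC3)C2=O)CC(C)(C)N1` gives 600 nM, and both sit within the scatter of compound 1: a 1.2-fold higher number from compound 1 to compound 2 (0.09 log units; within the scatter) and a 1.5-fold lower number from compound 1 to compound 3 (0.18 log units; within the scatter). Compound 4 `CCOC(=O)C1CCN(C(=O)CN2CN(c3ccccc3)C3(CCN(C(=O)c4ccc(C(C)(C)C)cc4)CC3)C2=O)CC1` differs from compound 1 in one place: tert-butyl in place of cyclohexyl on an aromatic carbon. For the measured compounds named here, none of the measured steps touches this aromatic carbon; all of them vary the group on the carbonyl carbon, so no measured step bears directly on the change. A step within the scatter is expected: a 1.3-fold higher number from compound 1 to compound 4 (0.12 log units; within the scatter). Compound 4 is therefore estimated at 1200 nM, with a range of 500 nM to 3000 nM.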

Compound 4, half-maximal inhibitory concentration: 3100 nM
For compound 4 the middle estimate is 2.6-fold (0.41 log units) below the measured one; the whole stated range lies below it.
By their numbers in this assay, from the lowest: compounds 3, 1 and 2 (each within the scatter of the next); then compound 4.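

Changes on the carbonyl carbon all stayed within the scatter, whereas in this assay tert-butyl in place of cyclohexyl on the aromatic carbon gives a 3.4-fold higher number from compound 1 to compound 4 (0.54 log units; beyond the scatter) and is the first single change in the series to exceed it. The group on this aromatic carbon therefore matters more here than the variations at the other end of compound 1. No evidence at hand accounts for the step.

Cyclohexyl and tert-butyl alone cannot separate the ring from the carbon count; cyclopentyl, phenyl or a longer chain such as n-hexyl would. Also open, going by these compounds, is whether the step holds with the carbonyl substituents of compound 2 and compound 3.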